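Ring-nitrogen substituents in a series at the limit

The source may report more compounds than this note shows. Statements on the series, on what has been measured and on what is new or still open speak of the compounds shown alone.

Compound 1 `O=C1COc2ccc(-c3cnc4ccccc4c3)cc2N1C1CCCCC1`: > 40000 nM (a limit)
Compound 2 `O=C1COc2ccc(-c3cnc4ccccc4c3)cc2N1`: > 40000 nM (a limit)

In a functional assay on HCT-116 cells (Homo sapiens) for antiproliferative activity, read by MTT assay, with a stated time of 72 h (a lower number here means a stronger inhibitor, a higher number a weaker inhibitor), compound 2 stands only as a limit, > 40000 nM. The evidence so far amounts to the limit of > 40000 nM in this assay, at which 2 of the 2 values shown sit. Going by the values given here, the one measured step, a step that the two limits leave unreadable from compound 1 to compound 2, has cyclohexyl leaving the amide-type nitrogen in a ring and gives no size to carry forward.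

Compound 3 `O=C1COc2ccc(-c3cnc4ccccc4c3)cc2N1c1ccc(Cl)cc1` has 4-chlorophenyl in place of hydrogen on that same nitrogen: 4-chlorophenyl in place of hydrogen on an amide-type nitrogen in a ring. The expectation rests on compound 2, a limit at > 40000 nM. With no number in the series, only a modest shift toward stronger inhibition is expected, and another limit reading is quite possible. The expected step is an at least 1.3-fold lower number from compound 2 to compound 3 (0.12 log units; that floor lies within the scatter). For compound 3 the estimate is 30000 nM, with an expected range of 5000 nM to 80000 nM.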

Compound 3, half-maximal inhibitory concentration: 36100 nM
Beside the measured number, compound 3's estimate is 1.2-fold (0.08 log units) below it; the range from low to high includes it.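

In this assay, going by these compounds alone, compound 3 gives 36100 nM, the first reading that is a number and not a limit, so the amide-type nitrogen in a ring can carry 4-chlorophenyl and still yield a measurable value. Going by these compounds, the change from hydrogen reads as an at least 1.1-fold lower number from compound 2 to compound 3 (0.04 log units; that floor lies within the scatter), and the change from cyclohexyl reads as an at least 1.1-fold lower number from compound 1 to compound 3 (0.04 log units; that floor lies within the scatter); each gives only a floor, so the true size of both steps stays unknown. Most of the series still rests at the assay limit: the limit of > 40000 nM in this assay, at which 2 of the 3 values shown sit.

The compounds shown leave open how unsubstituted phenyl, 4-methoxyphenyl or a longer chain ending in an amine would read on that same nitrogen. Also open, on these data alone, is whether any group at this position can give a step that clearly exceeds the scatter.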